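Benzyl in Place of Methyl on the Propargylamine Nitrogen

The compounds below may be only part of what the source reports. "The series", "measured", "known", "first", "only" and "open" are said of these compounds alone.

Among the measured compounds shown here, compound 2 `C#CCN(C)CCCOc1ccc2ccc(=O)oc2c1` gives 1090 nM in an assay on isolated protein for inhibition of Amine oxidase [flavin-containing] B (Homo sapiens), read by fluorescence and Amplex Red, with stated times of 15 min and 20 min (a higher number here means a weaker inhibitor, a lower number a stronger inhibitor), the lower of the two numbers measured so far. Compound 1 `C#CCN(CCCCOc1ccc2ccc(=O)oc2c1)Cc1cccc(OC)c1`, which differs from it in several places, gives 2340 nM in this assay, a gap beyond the scatter. Compound 3 `C#CCN(CCCOc1ccc2ccc(=O)oc2c1)Cc1ccccc1` is the next case: it carries phenyl in place of hydrogen on a saturated chain carbon bound to an amine nitrogen, a change that, cut one bond further out, reads methyl to benzyl. For the measured compounds named here, no measured pair shows this change alone. The step is expected to be a 1.5-fold higher number from compound 2 to compound 3 (0.17 log units; within the scatter), a modest weakening that may not clear the scatter. Compound 3 is therefore estimated at 1600 nM, within 500 nM to 5000 nM.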

Compound 3, half-maximal inhibitory concentration: 3740 nM
Estimate against measurement, compound 3: 2.3-fold (0.37 log units) below, within the range that was stated.
By their numbers in this assay, from the lowest: compound 2; then compounds 1 and 3 (each within the scatter of the next).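

In this assay, among the compounds shown here, the change from methyl to benzyl brings a 3.4-fold higher number from compound 2 to compound 3 (0.54 log units; beyond the scatter) and gives the first reading of this position on its own, with the other parts of compound 2 unchanged. Phenyl in place of hydrogen on this saturated chain carbon bound to an amine nitrogen thus weakens inhibition here, though compound 3 still gives a measurable number. Nothing measured here explains the loss. The compounds shown leave open how an ethyl or a phenethyl group would read at this position. They also leave open whether a fluorine or methoxy on the benzyl ring would alter the step.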